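A few compounds are considered here, and "the series" means these few. Any claim that something is new, unique, unknown or untested is made for them only; others in the source may bear on it.

Series notes, cytotoxicity. In an ADME assay on ECV-304 cells (Homo sapiens) for cytotoxicity, read by MTT assay, with a stated time of 72 h (a lower number here means a stronger inhibitor, a higher number a weaker inhibitor), compound 1 `COc1ccc(C2=C(c3cc(OC)c(OC)c(OC)c3)CC(O[SiH2]C(C)(C)C)C2=O)cc1[N+](=O)[O-]` sits at a limit of the assay, > 100 ug/mL, and not at a number. Compound 2 `COc1ccc(OC)c(C2=C(c3cc(OC)c(OC)c(OC)c3)C(=O)CC2O[SiH2]C(C)(C)C)c1` gives 6.5 ug/mL in this assay. Compound 3 `C=CCOc1cc(C2=C(c3cc(OC)c(OC)c(OC)c3)C(=O)C(O)C2)ccc1OC` likewise sits at a limit in this assay, > 100 ug/mL, so for compound 3 only a limit is known and no number. On the numbers shown, compound 3 therefore stands at the limit of > 100 ug/mL in this assay, at which 2 of the 3 values shown sit. Compound 2 is the only one of the three with a number. Among the compounds with values here, no two measured compounds differ in one place only, so no measured step gives a size to lean on.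

Compound 4 `COc1ccc(C2=C(c3cc(OC)c(OC)c(OC)c3)C(=O)C(O)C2)cc1` is the next compound, not yet measured in this assay. Against compound 3 the change is hydrogen in place of allyloxy on an aromatic carbon; it sits on an aromatic carbon of a six-membered aromatic ring of carbon only, ortho to a methoxy group and meta to a large group, while the carbonyl and the free hydroxyl of compound 3 are kept. Since compound 3 is only a limit, the direction of this step cannot be read from a measured pair. The expectation for compound 4 is a modest move toward a stronger inhibitor, an at least 2.0-fold lower number from compound 3 to compound 4 (0.30 log units; that floor lies within the scatter), with a fair chance that this assay again reports only a limit. The estimate for compound 4 in this assay is 50 ug/mL, expected to lie between 10 ug/mL and 200 ug/mL.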

Compound 4, half-maximal inhibitory concentration: < 1 ug/mL
Compound 4: a limit, no number (the forecaster's own chance of this, stated with the estimate: 50%); at least 50-fold (1.69 log units) between middle value and limit.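

In this assay, within the data shown here, the aromatic carbon ortho to a methoxy group and meta to a large group proves highly sensitive to what it carries: hydrogen in place of allyloxy, with the carbonyl and the free hydroxyl kept, gives an at least 100-fold lower number from compound 3 to compound 4 (2.00 log units; beyond the scatter) in the first single-place comparison of the series. Compound 3 sits at a limit of the assay and has no number: the limit of > 100 ug/mL in this assay, at which 2 of the 4 values shown sit. Compound 4 also sits at a limit of the assay and has no number: the limit of < 1 ug/mL in this assay, at which 1 of the 4 values shown sits.

The true size of the step remains open, as neither end is a number, and the compounds shown do not tell whether the loss of the whole allyloxy group, its oxygen or its double bond outside aromatic rings accounts for the difference. A propoxy chain on that same aromatic carbon would separate the double bond from the chain length, and an amine there would test a different kind of group, while a value for compound 4 from lower concentrations would fix the upper end of the comparison.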